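One group exchanged on compound 1

The source may report more compounds than this note shows. Statements on the series, on what has been measured and on what is new or still open speak of the compounds shown alone.

Compound 1 `COc1ccc(S(=O)(=O)Nc2ccc(-c3nc4cc(NS(=O)(=O)c5ccc(OC)cc5)ccc4o3)cc2)cc1` gives 12000 nM
Compound 2 `O=S(=O)(Nc1ccc(-c2nc3cc(NS(=O)(=O)c4ccc(Br)cc4)ccc3o2)cc1)c1ccc(Br)cc1` gives 11000 nM
Compound 3 `COc1c(Br)cccc1C(=O)Nc1ccc(Sc2nc3ccccc3s2)cc1` gives 31000 nM

In a functional assay on HCT-116 cells (Homo sapiens) for cytotoxicity, read by resazurin assay, with a stated time of 48 h (on this read-out higher numbers stand for an effect only at larger amounts of compound and lower numbers for an effect already at smaller amounts), compound 1 gives 12000 nM as its number, within the scatter of compound 2 at 11000 nM on the same read-out. Compound 3 at 31000 nM lies higher than compound 1, beyond the scatter. Compound 4 `COc1ccc(S(=O)(=O)Nc2ccc3oc(-c4ccc(NC(=O)C5CCN(C(C)=O)CC5)cc4)nc3c2)cc1` has not yet been measured. It differs from compound 1 by (1-acetylpiperidin-4-yl)carbonyl in place of (4-methoxyphenyl)sulfonyl on a nitrogen on an aromatic ring in all: (1-acetylpiperidin-4-yl)carbonyl in place of (4-methoxyphenyl)sulfonyl on a nitrogen on an aromatic ring. Going by the values given here, no two measured compounds differ in one place, so the data give no direct guide to this exchange. A small upward step is expected, with a 1.5-fold higher number from compound 1 to compound 4 (0.18 log units; within the scatter) as the estimate, not clearly beyond the scatter. Compound 4 is expected at 18000 nM in a range from 6000 nM to 50000 nM on this estimate.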

Compound 4, half-maximal effective concentration: 15000 nM
For compound 4 the middle estimate is 1.2-fold (0.08 log units) above the measured one, within the range that was stated.
By their numbers in this assay, from the lowest: compounds 2, 1 and 4 (each within the scatter of the next); then compound 3.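

In this assay the exchange of (4-methoxyphenyl)sulfonyl for (1-acetylpiperidin-4-yl)carbonyl on a nitrogen on an aromatic ring gives a 1.3-fold higher number from compound 1 to compound 4 (0.10 log units; within the scatter) and so stays within the scatter. This first one-place comparison shows that, at this nitrogen, an aromatic sulfonyl group and a non-aromatic carbonyl group give numbers that cannot be told apart. No measured evidence bears on this result. Still open, from the compounds shown here alone, is whether a free amine in place of the acetyl, or a carboxylic acid, would shift the number. Also open, going by these compounds, is whether the same exchange would read alike at the second (4-methoxyphenyl)sulfonyl group of compound 1.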